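The source may report more compounds than this note shows. Statements on the series, on what has been measured and on what is new or still open speak of the compounds shown alone.

Measured so far in a physicochemical assay for solubility, using the shake flask method, measured as kinetic solubility, with a stated time of 20 h, at pH 2 (a higher number here means a more soluble compound, a lower number a less soluble compound), each value a limit of the assay and not a number:
Compound 1 `COc1ccnc(Nc2cc3[nH]c(-c4cccc(C(F)(F)F)c4)nc3cn2)c1`: < 5000 nM
Compound 2 `FC(F)(F)c1ccc(Nc2cc3[nH]c(-c4cccc(C(F)(F)F)c4)nc3cn2)nc1`: < 5000 nM
Compound 3 `O=C(O)c1ccnc(Nc2cc3[nH]c(-c4cccc(C(F)(F)F)c4)nc3cn2)c1`: < 5000 nM

Compound 2 has no number to stand on, only its limit of < 5000 nM. For the measured compounds named here, the series so far rests on (the limit of < 5000 nM in this assay, at which 3 of the 3 values shown sit).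

The next compound is compound 4 `FC(F)(F)c1ccc(Nc2cc3[nH]c(C4CCCC4)nc3cn2)nc1`, where cyclopentyl takes the place of 3-(trifluoromethyl)phenyl on an aromatic carbon: cyclopentyl in place of 3-(trifluoromethyl)phenyl on an aromatic carbon.

The nearest measured changes are a step that the two limits leave unreadable from compound 1 to compound 2 and a step that the two limits leave unreadable from compound 2 to compound 3, with a step that the two limits leave unreadable from compound 1 to compound 3 as the third. None of them touches this aromatic carbon, and none gives a size. With no readable size to carry over, no step beyond the scatter is expected in this assay, and no direction can be assigned.

The expected change is a step that the limit leaves unreadable from compound 2 to compound 4, and it is an estimate made from a limit. In this assay compound 4 is estimated at 4000 nM, with an expected range of 1000 nM to 15000 nM.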

Compound 4, solubility: 132000 nM
For compound 4 the middle estimate is 33-fold (1.52 log units) below the measured one, outside the stated range (above it).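

In this assay, for the compounds shown here, the aromatic carbon between two ring nitrogen atoms is the first place where a change can be read: cyclopentyl in place of 3-(trifluoromethyl)phenyl gives an at least 26-fold higher number from compound 2 to compound 4 (1.42 log units; beyond the scatter). For compound 2, < 5000 nM is a limit of the assay and not a number, so this step gives only a minimum size. The steps among compound 1, compound 2 and compound 3 cannot be read, and compound 4 is the only one of the four with a number: the limit of < 5000 nM in this assay, at which 3 of the 4 values shown sit.

This change replaces an aromatic ring with a non-aromatic one, alters the ring size and removes the trifluoromethyl group all at once, and the compounds shown do not separate these differences. Unsubstituted phenyl, cyclohexyl or a piperidine amine at this carbon would begin to do so.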